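A Nitrophenyl Limit and a Bromophenyl Estimate

The source may report more compounds than this note shows. Statements on the series, on what has been measured and on what is new or still open speak of the compounds shown alone.

In a functional assay on QGY7701 cells (Homo sapiens) for cytotoxicity, read by MTT assay, with a stated time of 48 h (a lower number here means a stronger inhibitor, a higher number a weaker inhibitor), compound 1 `O=c1ccoc2cc(OCc3cn(Cc4cccc([N+](=O)[O-])c4)nn3)ccc12` gives 14100 nM. On these data alone, compound 2 `O=c1ccoc2cc(OCc3cn(Cc4ccc([N+](=O)[O-])cc4)nn3)ccc12` gives > 100000 nM, which is a limit of the assay and not a number, so its true value remains unknown. Among the measured compounds shown here, only one measured step bears on what follows: 4-nitrophenyl in place of 3-nitrophenyl produced an at least 7.0-fold higher number from compound 1 to compound 2 (0.85 log units; beyond the scatter). Compound 3 `O=c1ccoc2cc(OCc3cn(Cc4ccccc4Br)nn3)ccc12`, not yet measured, has 2-bromophenyl in place of 4-nitrophenyl on a saturated chain carbon bound to an aromatic nitrogen. For the measured compounds named here, no measured step covers a bromophenyl group, so the guide is thin. Still, compound 1 at 14100 nM shows that a number can be reached once 4-nitrophenyl is gone, and a modest move towards a lower number is expected. In this assay the estimated step is an at least 3.3-fold lower number from compound 2 to compound 3 (0.52 log units; beyond the scatter). Compound 3 is expected at about 30000 nM, within an estimated range of 8000 nM to 100000 nM.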

Compound 3, half-maximal inhibitory concentration: > 100000 nM
Compound 3: only a limit was reported; the forecaster's own chance of this, stated with the estimate: 30%; middle value at least 3.3-fold (0.52 log units) from the limit.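

In this assay compound 3 gives > 100000 nM, which is a limit of the assay and not a number. Among the compounds shown here, exchanging 3-nitrophenyl for 2-bromophenyl gives an at least 7.0-fold higher number from compound 1 to compound 3 (0.85 log units; beyond the scatter), so 4-nitrophenyl is no longer the only group here that stands apart from 3-nitrophenyl. Compound 1 is now the only one of the three to give a number, and the step between compound 2 and compound 3 cannot be read because both stand at the same limit: the limit of > 100000 nM in this assay, at which 2 of the 3 values shown sit.

On these data alone, whether 2-bromophenyl and 4-nitrophenyl differ at all stays open, as does how far either lies beyond the limit. As far as these compounds go, it is also open whether an amine or a carboxylic acid at this place would give a number, as 3-nitrophenyl does in compound 1.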